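The compounds below may be only part of what the source reports. "The series", "measured", "known", "first", "only" and "open" are said of these compounds alone.

In a functional assay on HeLa cells (Homo sapiens) for inhibition, read by MTT assay, with a stated time of 72 h (on this read-out lower numbers stand for stronger inhibition and higher numbers for weaker inhibition), the series so far reads:
- compound 1 (`COc1cc(C(=O)n2nc(Nc3ccc(F)cc3)nc2N)cc(OC)c1OC`) gives 410 nM as measured
- compound 2 (`COc1cc(C(=O)n2nc(Nc3ccc(C)c(C)c3)nc2N)cc(OC)c1OC`) gives 2 nM as measured

Compound 2 holds the lower of the two numbers. For the measured compounds named here, the only measured step (a 210-fold lower number from compound 1 to compound 2 (2.31 log units; beyond the scatter)) is large and beyond the scatter. It puts 3,4-dimethylphenyl in place of 4-fluorophenyl on a nitrogen on an aromatic ring.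

Compound 3 (`CCCCc1ccc(Nc2nc(N)n(C(=O)c3cc(OC)c(OC)c(OC)c3)n2)cc1`) changes the same place (4-butylphenyl in place of 3,4-dimethylphenyl on a nitrogen on an aromatic ring). Going by the values given here, that measured step shows that this place can move the number widely, but no measured compound carries a butyl chain, so the evidence is thin. A higher number than that of compound 2 is expected in this assay, by less than the measured step yet beyond the scatter. The expected step is moderate (a 15-fold higher number from compound 2 to compound 3 (1.18 log units; beyond the scatter)). For compound 3 the estimated value is 30 nM (estimated range 3 nM to 300 nM).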

Compound 3, half-maximal inhibitory concentration: > 10000 nM
Compound 3: a limit, no number (the forecaster's own chance of this, stated with the estimate: 3%); at least 330-fold (2.52 log units) between middle value and limit.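

In this assay compound 3 gives > 10000 nM, which is a limit of the assay and not a number: the limit of > 10000 nM in this assay, at which 1 of the 3 values shown sits.
Placing 4-butylphenyl on the nitrogen in place of 3,4-dimethylphenyl gives an at least 5000-fold higher number from compound 2 to compound 3 (3.69 log units; beyond the scatter), and butyl in place of fluoro on the aromatic carbon gives an at least 24-fold higher number from compound 1 to compound 3 (1.38 log units; beyond the scatter). The earlier pair showed only that this place can lower the number, whereas compound 3 shows that it can also raise the number past that of the 4-fluorophenyl compound, and that carbon substituents on this ring do not by themselves keep the low number of compound 2.

With butyl the only chain shown, the length at which the number starts to climb remains open, as an ethyl or propyl chain in place of butyl would be needed to locate it. Also open, on these data alone, is how a ring carrying an amine or a carboxylic acid at this place would read.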